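A Bromine Swapped for a Methoxypyridine on the Shared Core

The source may report more compounds than this note shows. Statements on the series, on what has been measured and on what is new or still open speak of the compounds shown alone.

Compound 1 `Nc1ccc(S(=O)(=O)N2CCN(c3ncc(C(O)(C(F)(F)F)C(F)(F)F)cc3Br)CC2)cn1` carries a bromo group on its core. In an ADME assay (liver) for metabolic stability, with Liver microsome (Homo sapiens) as the target, using microsomes and NADPH, with a stated time of 30 min, tested at 1 uM (on this read-out higher numbers stand for fast clearance and lower numbers for slow clearance), compound 1 gives < 14 mL.min-1.g-1, which is a limit of the assay and not a number. Its reading sits at the limit of < 14 mL.min-1.g-1 in this assay, at which 1 of the 3 values shown sits. Compound 2 `Nc1ccc(S(=O)(=O)N2CCN(c3ncc(C(O)(C(F)(F)F)C(F)(F)F)cc3-c3cccnc3)CC2)cn1` has pyridin-3-yl in place of bromo on an aromatic carbon, and in this assay compound 2 gives 17 mL.min-1.g-1. Compound 3 `Nc1ccc(S(=O)(=O)N2CCN(c3ncc(C(O)(C(F)(F)F)C(F)(F)F)cc3-c3cncc(F)c3)CC2)cn1` has 5-fluoropyridin-3-yl in the same place, and in this assay compound 3 gives 24 mL.min-1.g-1. The measured steps are an at least 1.2-fold higher number from compound 1 to compound 2 (0.08 log units; that floor lies within the scatter) and an at least 1.7-fold higher number from compound 1 to compound 3 (0.23 log units; that floor lies within the scatter), while a 1.4-fold higher number from compound 2 to compound 3 (0.15 log units; within the scatter) is small.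

Compound 4 `COc1ccc(-c2cc(C(O)(C(F)(F)F)C(F)(F)F)cnc2N2CCN(S(=O)(=O)c3ccc(N)nc3)CC2)cn1` differs from compound 1 as follows: 6-methoxypyridin-3-yl in place of bromo on an aromatic carbon. The two measured steps that put an aromatic ring in place of bromo both bear on this change, and both give floors that stay within the scatter. A modest rise or no clear change is therefore expected. For compound 4 a value of 22 mL.min-1.g-1 is estimated, with a range from 10 mL.min-1.g-1 to 48 mL.min-1.g-1. This estimate corresponds to an expected at least 1.5-fold higher number from compound 1 to compound 4 (0.19 log units; that floor lies within the scatter).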

Compound 4, intrinsic clearance in microsomes: 25 mL.min-1.g-1
Compound 4: middle estimate off by 1.1-fold (0.06 log units), on the low side; low and high end bracket the measured number.
By their numbers in this assay, from the lowest: compounds 2, 3 and 4 (each within the scatter of the next). At a limit, below all of these: compound 1.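

At this position of the shared core, three pyridine rings now give readings in this assay that cannot be told apart: adding methoxy to the plain pyridine ring gives a 1.5-fold higher number from compound 2 to compound 4 (0.17 log units; within the scatter), and exchanging the fluoro-bearing ring for the methoxy-bearing one gives a 1.0-fold higher number from compound 3 to compound 4 (0.02 log units; within the scatter). Among the compounds shown here, the 6-methoxypyridin-3-yl group is thus the largest group at this position so far, yet neither of these steps goes beyond the scatter. Against bromo there is only a floor, an at least 1.7-fold higher number from compound 1 to compound 4 (0.25 log units; that floor lies within the scatter), and compound 1 is a limit of the assay and not a number.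

Whether any of these rings truly gives a higher number than bromo remains unsettled, with every floor within the scatter. On these data alone, it is also open how an amine or a carboxylic acid on the added pyridine ring would read in this assay.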